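The source may hold more compounds than are shown below. What is called first, only, known or untested is meant among the compounds shown, and "the series" means these compounds.

Values so far in a physicochemical assay for solubility, read by HPLC, in phosphate buffer, at pH 6.5; a lower number here means a less soluble compound, a higher number a more soluble compound:
compound 1 `COC(=O)C1=C(C)NC(c2nccs2)=NC1(C)c1ccc(F)cc1` gives 22 ug/mL
compound 2 `COC(=O)C1=C(C)NC(c2nccs2)=NC1(C)c1ccc(Cl)cc1` gives 14 ug/mL
compound 3 `COC(=O)C1=C(C)NC(c2nccs2)=NC1(C)c1ccc(OC)cc1` gives 106 ug/mL

Compound 3 stands highest of the three, beyond the scatter from both others. Compound 4 `COC(=O)C1=C(C)NC(c2nccs2)=NC1(C)c1ccc(C#N)cc1` differs from it by cyano in place of methoxy on an aromatic carbon, para to a large group (cyano in place of methoxy on an aromatic carbon). Among the compounds with values here, no measured step involves cyano, so the evidence is indirect. Two modest steps end on methoxy (a 4.8-fold higher number from compound 1 to compound 3 (0.68 log units; beyond the scatter)) and (a 7.6-fold higher number from compound 2 to compound 3 (0.88 log units; beyond the scatter)), whereas the step between fluoro and chloro stays within the scatter (a 1.6-fold lower number from compound 1 to compound 2 (0.20 log units; within the scatter)). Leaving methoxy may therefore give back a modest step downward, though cyano itself remains untested. The expected change is (a 4.2-fold lower number from compound 3 to compound 4 (0.63 log units; beyond the scatter)). For compound 4 the estimated value is 25 ug/mL with an expected range (8 ug/mL to 80 ug/mL).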

Compound 4, solubility: 87 ug/mL
Compound 4: middle estimate off by 3.5-fold (0.54 log units), on the low side, outside the stated range (above it).
By their numbers in this assay, from the lowest: compounds 2 and 1 (each within the scatter of the next); then compounds 4 and 3 (each within the scatter of the next).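

At the aromatic carbon para to a large group, the high solubility of compound 3 turns out not to be unique to methoxy in this assay, as cyano in its place leaves the number within the scatter (a 1.2-fold lower number from compound 3 to compound 4 (0.09 log units; within the scatter)). Cyano also stands clear of both chloro (a 6.2-fold higher number from compound 2 to compound 4 (0.79 log units; beyond the scatter)) and fluoro (a 4.0-fold higher number from compound 1 to compound 4 (0.60 log units; beyond the scatter)), so methoxy and cyano group together, apart from the two halogens. Nothing at hand explains this grouping. From the compounds shown here alone, whether an amine, a carboxylic acid or a longer chain such as butoxy at this carbon would join the upper pair or the lower pair remains open.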